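This account rests on a few compounds, and the source may have more. Where it says the series, first, only, none or still open, it means among the compounds named here.

Measured in a functional assay on the whole organism (strain Wistar) for inhibition, with Rattus norvegicus as the target, read by paw edema, with a stated time of 3 h, at a dose of 100 mg/kg; a higher number here means more inhibition at the dose given (going by the name of the read-out), a lower number less inhibition:
compound 1, `COc1cc2c(cc1OC)C(CC(=O)Nc1ccccc1)CC2`: 36.2%
compound 2, `COc1cc2c(cc1OC)C(CC(=O)Nc1cccc(Cl)c1)CC2`: 24.6%
compound 3, `COc1cc2c(cc1OC)C(CC(=O)Nc1cccc(C)c1)CC2`: 37.7%

Compound 3 gives the highest of the three numbers in this assay, but the gap to compound 1 is small, a number 1.5 percentage points higher from compound 1 to compound 3 (within the scatter), so those two cannot be ordered. Only compound 2 stands clearly apart: a number 13.1 percentage points higher from compound 2 to compound 3 (beyond the scatter), and against compound 1 the same compound shows a number 11.6 percentage points lower from compound 1 to compound 2 (beyond the scatter).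

Compound 4, `COc1cc2c(cc1OC)C(CC(=O)Nc1ccccn1)CC2`, carries pyridin-2-yl in place of 3-methylphenyl on an amide-type nitrogen. None of the three measured steps bears directly on this change: each of them swaps hydrogen, chloro or methyl on an aromatic carbon and keeps a ring of carbon only, whereas here the methyl leaves and a six-membered aromatic ring with one hetero atom, a nitrogen, enters on the amide-type nitrogen. Going by the values given here, the measured steps show only that a change on this ring can lower the read-out by a modest amount or leave it unchanged. The estimated step is a number 4.7 percentage points lower from compound 3 to compound 4 (within the scatter): compound 4 is expected to stay within the scatter of its parent, with a wide range kept for lack of a matching precedent. For compound 4 the expected value in this assay is 33%, between 20% and 46%.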

Compound 4, a percentage reported as inhibition, in the whole organism at one dose (the size of the read-out at that dose, not a potency): 30.4%
For compound 4 the middle estimate is 2.6 percentage points above the measured one; the range from low to high includes it.
By their numbers in this assay, from the lowest: compounds 2, 4, 1 and 3 (each within the scatter of the next, the first and the last beyond it).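

In this assay, going by these compounds alone, this is the first change of the ring on the amide-type nitrogen itself rather than of a group on that ring, and pyridin-2-yl brings in a ring nitrogen and a hydrogen-bond acceptor without a step beyond the scatter against any of the three earlier compounds: (a number 7.3 percentage points lower from compound 3 to compound 4 (within the scatter)), (a number 5.8 percentage points lower from compound 1 to compound 4 (within the scatter)) and (a number 5.8 percentage points higher from compound 2 to compound 4 (within the scatter)). Compound 4 therefore cannot be separated from compound 1, compound 2 or compound 3, even though compound 2 stands clearly apart from the other two, so at this position a ring of carbon only is not required to keep the read-out within the range seen so far. Nothing available explains these values or links them to any property of the groups.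

Still open, from the compounds shown here alone, is whether pyridin-3-yl or pyridin-4-yl on the same nitrogen would read like compound 4, and whether a carboxylic acid or an amine on the phenyl ring would move the number beyond the scatter in either direction. Going by these compounds, the values are sizes of effect at a single dose and time, not potencies, so how the four compounds would compare across a range of doses also remains open.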